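The compounds below may be only part of what the source reports. "The series", "measured", "known", "first", "only" and "open" are said of these compounds alone.

Compound 1 `O=C1/C(=C\c2ccccc2)S/C(=N/c2ccccc2)N1Cc1ccncc1`: 64700 nM
Compound 2 `COc1ccc(/C=C2/S/C(=N/c3ccccc3)N(Cc3ccncc3)C2=O)cc1OC`: 171000 nM
Compound 3 `COc1ccc(OC)c(/C=C2/S/C(=N/c3ccccc3)N(Cc3ccncc3)C2=O)c1`: 80100 nM

These three compounds share one core and differ only in the aromatic group on the double-bonded chain carbon. In an ADME assay on HEK293 cells (Homo sapiens) for cytotoxicity, read by MTT assay, with a stated time of 48 h (on this read-out lower numbers stand for stronger inhibition and higher numbers for weaker inhibition), compound 3 gives 80100 nM, a number within the usual scatter of compound 1. Both lie lower than compound 2, as the measured 2.1-fold lower number from compound 2 to compound 3 (0.33 log units; beyond the scatter) shows.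

The next compound, compound 4 `O=C1/C(=C\c2cccc(Cl)c2)S/C(=N/c2ccccc2)N1Cc1ccncc1`, changes that same group again: 3-chlorophenyl in place of 2,5-dimethoxyphenyl on a double-bonded chain carbon bound to a double-bonded ring carbon. In words, it carries 3-chlorophenyl in place of 2,5-dimethoxyphenyl on a double-bonded chain carbon bound to a double-bonded ring carbon.

All three measured steps were made at this place. Besides the one above, they are a 2.6-fold higher number from compound 1 to compound 2 (0.42 log units; beyond the scatter) and a 1.2-fold higher number from compound 1 to compound 3 (0.09 log units; within the scatter). Changes here have therefore been modest at most, and one stayed within the scatter. Among the compounds with values here, no measured compound carries 3-chlorophenyl, so its own contribution remains unknown, and the range must stay wide. In this assay, a step beyond the scatter is therefore not expected. The expected result is a 1.1-fold lower number from compound 3 to compound 4 (0.06 log units; within the scatter). For compound 4 the estimated value is 70000 nM, with an expected range from 30000 nM to 150000 nM.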

Compound 4, half-maximal inhibitory concentration: 71800 nM
Compound 4: middle estimate off by 1.0-fold (0.01 log units), on the low side; measured number inside the range.
By their numbers in this assay, from the lowest: compounds 1, 4 and 3 (each within the scatter of the next); then compound 2.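

In this assay, chloro in place of hydrogen on an aromatic carbon gives a 1.1-fold higher number from compound 1 to compound 4 (0.05 log units; within the scatter) and so does not move the number beyond the scatter. Exchanging 2,5-dimethoxyphenyl for 3-chlorophenyl, a group with fewer heavy atoms and no hydrogen-bond acceptors, also stays within the scatter, with a 1.1-fold lower number from compound 3 to compound 4 (0.05 log units; within the scatter) as the step, so quite different groups at this place can give closely matching numbers. Only compound 2 stands apart among the four, as a 2.4-fold lower number from compound 2 to compound 4 (0.38 log units; beyond the scatter) shows, and the presence of two methoxy groups alone does not account for this, as compound 3 also carries two and stays within the scatter of compounds 1 and 4; no measurement at hand explains the separate position of compound 2.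

The compounds shown leave open whether an amine or a carboxylic acid on this aromatic ring, or a saturated ring such as cyclohexyl in its place, would shift the number beyond the scatter. They also leave open how much changes elsewhere on the shared core would matter, as all four compounds differ only at this one place.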